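A Hydroxylated Benzyl Group Replaces the Difluorinated One

The source may hold more compounds than are shown below. What is called first, only, known or untested is meant among the compounds shown, and "the series" means these compounds.

In a functional assay on CCRF-CEM cells (Homo sapiens) for antiproliferative activity, with a stated time of 72 h (on this read-out lower numbers stand for stronger inhibition and higher numbers for weaker inhibition), compound 1 (`OC[C@H]1O[C@@H](n2cnc3c(NCc4ccc(F)cc4)ncnc32)[C@H](O)[C@@H]1O`) gives 1250 nM and compound 2 (`Cc1cccc(CNc2ncnc3c2ncn3[C@@H]2O[C@H](CO)[C@@H](O)[C@H]2O)c1`) gives 19100 nM. Compound 3 (`OC[C@H]1O[C@@H](n2cnc3c(NCc4ccc(F)cc4F)ncnc32)[C@H](O)[C@@H]1O`) lies between them at 7100 nM. Compound 4 (`Cc1cccc(CNc2ncnc3c2ncn3[C@@H]2O[C@H](CO)[C@@H](O)[C@H]2O)c1O`) has 2-hydroxy-3-methylphenyl in place of 2,4-difluorophenyl on a saturated chain carbon bound to a nitrogen on an aromatic ring. Two measured changes of this group bear on it: a 2.7-fold lower number from compound 2 to compound 3 (0.43 log units; beyond the scatter), and the larger 15-fold higher number from compound 1 to compound 2 (1.18 log units; beyond the scatter). Going by the values given here, no measured compound carries the hydroxy group on this ring, so the direction stays open, and no step beyond the scatter is expected. The expected change is a 1.2-fold lower number from compound 3 to compound 4 (0.07 log units; within the scatter). For compound 4 the estimated value is 6000 nM, with an expected range of 1500 nM to 24000 nM.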

Compound 4, half-maximal inhibitory concentration: 900 nM
Beside the measured number, compound 4's estimate is 6.7-fold (0.82 log units) above it; the measured number lies below the stated range.
By their numbers in this assay, from the lowest: compounds 4 and 1 (each within the scatter of the next); then compound 3; then compound 2.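

In this assay, adding a hydroxy group to the 3-methylphenyl group gives the step seen in the matched pair (a change of a 21-fold lower number from compound 2 to compound 4 (1.33 log units; beyond the scatter)). The same 2-hydroxy-3-methylphenyl group also improves on 2,4-difluorophenyl (a change of a 7.9-fold lower number from compound 3 to compound 4 (0.90 log units; beyond the scatter)), yet it stays within the scatter of 4-fluorophenyl (a change of a 1.4-fold lower number from compound 1 to compound 4 (0.14 log units; within the scatter)). No available measurement accounts for the effect of the hydroxy group. The compounds shown leave open whether a methoxy group or an amine could stand for the hydroxy group on this ring. They also leave open whether the hydroxy group keeps its effect without the methyl group.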